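The source may hold more compounds than are shown below. What is called first, only, known or untested is meant among the compounds shown, and "the series" means these compounds.

Three compounds that share one core and differ only in the aromatic group on a saturated chain carbon bound to a nitrogen on an aromatic ring have been tested in a functional assay on HOS cells (Homo sapiens) for antiproliferative activity, with a stated time of 72 h; on this read-out higher numbers stand for weaker inhibition and lower numbers for stronger inhibition. Compound 1 `OC[C@H]1O[C@@H](n2cnc3c(NCc4ccccc4F)ncnc32)[C@H](O)[C@@H]1O`, with 2-fluorophenyl, reports only a limit, > 166000 nM. Compound 2 `OC[C@H]1O[C@@H](n2cnc3c(NCc4ccc(F)cc4)ncnc32)[C@H](O)[C@@H]1O`, with 4-fluorophenyl, gives a real number, 13200 nM. Compound 3 `COc1cccc(CNc2ncnc3c2ncn3[C@@H]2O[C@H](CO)[C@@H](O)[C@H]2O)c1OC`, with 2,3-dimethoxyphenyl, also reports only a limit, > 166000 nM. Compound 3 therefore stands at the limit of > 166000 nM in this assay, at which 2 of the 3 values shown sit, and its true position cannot be read.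

Compound 4 `OC[C@H]1O[C@@H](n2cnc3c(NCc4cccc(O)c4O)ncnc32)[C@H](O)[C@@H]1O` has 2,3-dihydroxyphenyl in place of 2,3-dimethoxyphenyl on a saturated chain carbon bound to a nitrogen on an aromatic ring. Within the data shown here, no measured pair makes this exact swap. The closest guides are two changes of the same group, an at least 12-fold lower number from compound 1 to compound 2 (1.09 log units; beyond the scatter) and an at least 12-fold higher number from compound 2 to compound 3 (1.09 log units; beyond the scatter). Both are large, so this position can clearly move the number a long way, though neither step predicts the effect of this particular swap. Since compound 3 sits at a limit, a readable result for compound 4 can only lie on the lower side, and a second limit remains quite possible. The expected change is an at least 6.6-fold lower number from compound 3 to compound 4 (0.82 log units; beyond the scatter). The estimate for compound 4 is 25000 nM, with an expected range of 3000 nM to 166000 nM.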

Compound 4, half-maximal inhibitory concentration: > 166000 nM
Compound 4: no number, only a limit; the forecaster's own chance of this, stated with the estimate: 35%; middle value at least 6.6-fold (0.82 log units) away from the limit.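

In this assay, replacing 2,3-dimethoxyphenyl with 2,3-dihydroxyphenyl on this saturated chain carbon takes the hydrogen-bond donors on the group from 0 to 2, yet compound 4 still reports only a limit. Changing 4-fluorophenyl to 2,3-dihydroxyphenyl gives an at least 12-fold higher number from compound 2 to compound 4 (1.09 log units; beyond the scatter), while the steps to compound 4 from compound 1 and from compound 3 join two limits and cannot be read. Compound 2 therefore remains the only one of the four with a real number, and the other three gather at a single ceiling: the limit of > 166000 nM in this assay, at which 3 of the 4 values shown sit.

As far as these compounds go, how far compound 1, compound 3 and compound 4 truly differ from one another stays unknown, so the dimethoxy and dihydroxy groups cannot be ranked against each other or against 2-fluorophenyl. From the compounds shown here alone, it is also open whether the real number in compound 2 depends on fluorine itself or would survive with a plain phenyl, 4-chlorophenyl or 4-methoxyphenyl group at this place.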